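Ring nitrogen acylation in a nitrophenyl dihydropyrimidine series

This account rests on a few compounds, and the source may have more. Where it says the series, first, only, none or still open, it means among the compounds named here.

Measured so far in an assay on HEK293 cells for antagonist activity at Voltage-dependent L-type calcium channel subunit alpha-1C (Oryctolagus cuniculus), read by FLIPR; on this read-out lower numbers stand for stronger inhibition and higher numbers for weaker inhibition: compound 1 `COC(=O)C1=C(C)NC(=O)NC1c1cccc([N+](=O)[O-])c1` gives 11700 nM; compound 2 `COC(=O)C1=C(C)NC(=S)NC1c1cccc([N+](=O)[O-])c1` gives 55000 nM; compound 3 `CC1=C(C(=O)OC(C)C)C(c2cccc([N+](=O)[O-])c2)NC(=S)N1` gives 10700 nM.

Compound 3 holds the lowest number of the three, within the scatter of compound 1 and set apart from compound 2 by a 5.1-fold lower number from compound 2 to compound 3 (0.71 log units; beyond the scatter). Compound 4 `COC(=O)N1C(=S)NC(C)=C(C(=O)OC(C)C)C1c1cccc([N+](=O)[O-])c1` differs from compound 3 by methoxycarbonyl in place of hydrogen on an amide-type nitrogen in a ring. Among the compounds with values here, no measured step touches this ring nitrogen; the only step, a 5.1-fold lower number from compound 2 to compound 3 (0.71 log units; beyond the scatter), concerns the ester alkyl and does not bear on it. With nothing comparable to go on, the expectation for compound 4 is a change no larger than the scatter, in either direction. Compound 4 is therefore estimated at 10000 nM (range 3000 nM to 40000 nM), a step of a 1.1-fold lower number from compound 3 to compound 4 (0.03 log units; within the scatter), which is an expectation rather than a measurement.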

Compound 4, half-maximal inhibitory concentration: 350 nM
Estimate against measurement, compound 4: 29-fold (1.46 log units) above; the whole stated range lies above it.
By their numbers in this assay, from the lowest: compound 4; then compounds 3 and 1 (each within the scatter of the next); then compound 2.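

In this assay the amide-type nitrogen in the ring, next to the ring atom that bears a 3-nitrophenyl group, accepts a substituent, and methoxycarbonyl in place of hydrogen there brings a large gain (a 31-fold lower number from compound 3 to compound 4 (1.49 log units; beyond the scatter)). Within the data shown here, the only earlier step (a 5.1-fold lower number from compound 2 to compound 3 (0.71 log units; beyond the scatter)) concerned the ester alkyl, so this is the first reading at this nitrogen, and the hydrogen there proves unnecessary for activity. Nothing measured here explains the gain.

Open, as far as these compounds go, is whether the gain needs the whole methoxycarbonyl, since an acetyl or a plain methyl on this nitrogen would separate its parts. Also open, from the compounds shown here alone, is whether it carries over to the methyl ester or to the ring carbonyl of compound 1.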